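Ethoxycarbonyl for cyclohexyl at the assay limit

A few compounds are considered here, and "the series" means these few. Any claim that something is new, unique, unknown or untested is made for them only; others in the source may bear on it.

Compound 1 (`Cc1cc(C)cc(S(=O)(=O)c2c(C(=O)NCC(=O)NN)[nH]c3ccc(Cl)cc23)c1`), compound 2 (`CNNC(=O)c1[nH]c2ccc(Cl)cc2c1S(=O)(=O)c1cc(C)cc(C)c1`) and compound 3 (`Cc1cc(C)cc(S(=O)(=O)c2c(C(=O)NNC3CCCCC3)[nH]c3ccc(Cl)cc23)c1`) share one core and were tested in a functional assay on MT4 cells (Homo sapiens) for cytotoxicity, read by MTT assay (on this read-out higher numbers stand for lower toxicity in this test and lower numbers for higher toxicity in this test), under the same conditions. Compound 1 gives > 100 uM as a limit of the test. Compound 2 gives > 100 uM as a limit too. Compound 3, the starting point here, gives > 100 uM as a limit as well. Compound 4 (`CCOC(=O)NNC(=O)c1[nH]c2ccc(Cl)cc2c1S(=O)(=O)c1cc(C)cc(C)c1`) carries ethoxycarbonyl in place of cyclohexyl on an amine nitrogen. The closest measured change is a step that the two limits leave unreadable from compound 2 to compound 3 at that same nitrogen. The other two, a step that the two limits leave unreadable from compound 1 to compound 3 and a step that the two limits leave unreadable from compound 1 to compound 2 likewise, have no readable size. Compound 3 sits with the others at the limit of > 100 uM in this assay, at which 3 of the 3 values shown sit, and no step size carries over, so a number no higher from compound 3 to compound 4 (the limit leaves the size open) is expected to stay within the scatter in this assay with no direction. Compound 4 is estimated at 100 uM (expected range 40 uM to 250 uM).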

Compound 4, half-maximal toxic concentration: 100 uM
Estimate against measurement, compound 4: no gap at the digits printed; measured number inside the range.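

In this assay, among the compounds shown here, compound 4 gives 100 uM, the first true number at this amine nitrogen, so with ethoxycarbonyl in place of cyclohexyl the reading falls on the scale of the test rather than at its edge. Compound 3 gives > 100 uM, which is a limit of the test. No step to compound 4 can be read in size, neither a number no higher from compound 2 to compound 4 (the limit leaves the size open) nor a number no higher from compound 1 to compound 4 (the limit leaves the size open), because the other compounds all stay at one ceiling: the limit of > 100 uM in this assay, at which 3 of the 4 values shown sit.

As far as these compounds go, with a number no higher from compound 3 to compound 4 (the limit leaves the size open), whether a longer chain or a carboxylic acid on this nitrogen would give a number well beyond the scatter from that of compound 4 stays open.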